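The source may hold more compounds than are shown below. What is called first, only, known or untested is meant among the compounds shown, and "the series" means these compounds.

Measured compounds and their values:
compound 1, `COc1cc(-c2nn(-c3cccc(NC(=O)Nc4cc(C(F)(F)F)cc(C(F)(F)F)c4)c3)cc2-c2ccncc2)ccc1Cl`, 524 nM
compound 2, `COc1cc(-c2nn(-c3cccc(NC(=O)Nc4ccc(Cl)c(Cl)c4)c3)cc2-c2ccncc2)ccc1Cl`, 931 nM
compound 3, `O=C(Nc1cccc(-n2cc(-c3ccncc3)c(-c3ccc(Cl)c(O)c3)n2)c1)Nc1ccc(Cl)c(Cl)c1`, 1210 nM

All three numbers come from a functional assay on OVCAR-8 cells (Homo sapiens) for inhibition, read by sulforhodamine B assay, with a stated time of 48 h; a higher number here means a weaker inhibitor of growth, a lower number a stronger inhibitor of growth. Compound 3 gives the highest number of the three. Against compound 2 the gap is a 1.3-fold higher number from compound 2 to compound 3 (0.11 log units; within the scatter), for hydrogen in place of methyl on an oxygen on an aromatic ring. Against compound 1 the gap is beyond the scatter, with compound 1 giving the lower number, but the two structures differ in more than one place and no single step connects them.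

Compound 4, `O=C(Nc1cccc(-n2cc(-c3ccncc3)c(-c3ccc(Cl)c(O)c3)n2)c1)Nc1ccc(Cl)c(C(F)(F)F)c1`, is not yet measured. It differs from compound 3 by trifluoromethyl in place of chloro on an aromatic carbon: read one bond further out, 3,4-dichlorophenyl becomes 4-chloro-3-(trifluoromethyl)phenyl. Among the compounds with values here, no measured step in this assay carries exactly this change. Within the data shown here, the only bearing comes from compounds 1 and 2, which carry trifluoromethyl and chloro substitution on the same aryl urea and whose values fall beyond the scatter apart, with the trifluoromethyl compound lower. On that slim basis a step no larger than the scatter, leaning toward a lower number, is expected for a 1.3-fold lower number from compound 3 to compound 4 (0.13 log units; within the scatter). Compound 4 is therefore estimated at 900 nM, within 400 nM to 2000 nM.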

Compound 4, concentration for 50% growth inhibition: 759 nM
The estimate for compound 4 lay 1.2-fold (0.07 log units) above the measured number, and the stated range covers the measured number.
By their numbers in this assay, from the lowest: compounds 1, 4, 2 and 3 (each within the scatter of the next, the first and the last beyond it).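

Trifluoromethyl in place of chloro, ortho to a chloro group on the aryl urea, can now be read directly in this assay as a single change: the step is a 1.6-fold lower number from compound 3 to compound 4 (0.20 log units; within the scatter). Compounds 1 and 2 differ in more than one place and could not isolate this change, whereas here the hydroxy group and the rest of the shared core stay fixed. Four heavy atoms enter where one leaves without a step beyond the scatter, so this position accepts trifluoromethyl in this one matched pair, and nothing available explains that outcome.

Whether the same change stays within the scatter when methoxy replaces the hydroxy group remains open, since the compounds shown contain no methoxy partner carrying 4-chloro-3-(trifluoromethyl)phenyl. Also open, going by these compounds, is whether a nitrile, a dimethylamino group or a carboxylic acid at this position, in place of trifluoromethyl, would shift the number beyond the scatter, as the present pair covers only chloro and trifluoromethyl.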